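The source may hold more compounds than are shown below. What is called first, only, known or untested is meant among the compounds shown, and "the series" means these compounds.

Measured so far in a functional assay for agonist activity at G protein-coupled receptor 88 (Homo sapiens), read by HTRF and cAMP accumulation; on this read-out lower numbers stand for an effect already at smaller amounts and higher numbers for an effect only at larger amounts of compound:
compound 1 `CCC(CC)C(N)CCN(C(=O)[C@@H]1C[C@H]1c1ccccc1)c1ccc(-c2ccccc2)cc1` — 2 nM
compound 2 `O=C([C@@H]1C[C@H]1c1ccccc1)N(CCNCC1CCCCC1)c1ccc(-c2ccccc2)cc1` — 6.6 nM

Compound 2 holds the highest number of the two, with compound 1 as the nearest point; the step of a 3.3-fold higher number from compound 1 to compound 2 (0.52 log units; beyond the scatter) is beyond the scatter and comes from exchanging the 1-amino-2-ethylbutyl group for (cyclohexylmethyl)amino.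

Compound 3 `O=C([C@@H]1C[C@H]1c1ccccc1)N(CCNCC1CCCC1)c1ccc(-c2ccccc2)cc1` differs from compound 2 only in the ring on the chain: cyclopentyl in place of cyclohexyl on a saturated chain carbon bound to an amine nitrogen. Seen one bond further out, this is (cyclohexylmethyl)amino becoming (cyclopentylmethyl)amino.

For the measured compounds named here, no measured step addresses this exchange directly. Going by the values given here, the only step in hand, a 3.3-fold higher number from compound 1 to compound 2 (0.52 log units; beyond the scatter), concerns a different and larger rebuild of the amine substituent, so it serves merely as a scale: even that larger change moved this assay by a modest amount. A cyclohexyl-to-cyclopentyl trim is smaller in kind, and the expectation is therefore a step of a 1.2-fold higher number from compound 2 to compound 3 (0.08 log units; within the scatter), that is, nothing clearly beyond the scatter in either direction.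

Compound 3 is thus expected to give about 8 nM, with a range of 3 nM to 22 nM.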

Compound 3, half-maximal effective concentration: 2.5 nM
Compound 3: the middle estimate sits 3.2-fold (0.51 log units) above what was measured, outside the stated range (below it).
By their numbers in this assay, from the lowest: compounds 1 and 3 (each within the scatter of the next); then compound 2.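

In this assay, for the compounds shown here, the ring on a saturated chain carbon bound to an amine nitrogen turns out to be a place where even a small exchange can be read: cyclopentyl in place of cyclohexyl gives a 2.6-fold lower number from compound 2 to compound 3 (0.42 log units; beyond the scatter) and so registers beyond the scatter, whereas the earlier compounds offered no comparison of ring size at this position. The (cyclopentylmethyl)amino compound also cannot be separated from the 1-amino-2-ethylbutyl compound, with a 1.3-fold higher number from compound 1 to compound 3 (0.10 log units; within the scatter) lying within the scatter, so of these three amine substituents, only (cyclohexylmethyl)amino stands apart, as shown by the ring exchange above and by a 3.3-fold higher number from compound 1 to compound 2 (0.52 log units; beyond the scatter). No available measurement explains why the five-membered ring and the six-membered ring differ in this assay.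

Going by these compounds alone, with only one pair of ring sizes in hand, it remains open whether a cyclobutyl or cyclopropyl ring would follow the same direction or whether the cyclopentyl ring is a local optimum. On these data alone, it is equally open how an open chain such as isobutyl, or a tetrahydropyranyl ring carrying an oxygen atom, would read at this same place.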